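Ester-to-amide step and a methoxymethyl follow-up

The source may report more compounds than this note shows. Statements on the series, on what has been measured and on what is new or still open speak of the compounds shown alone.

Measured so far:
- compound 1 `CCOC(=O)c1c(C)coc1-c1ccc2c(CC)cccc2c1OC`: in a functional assay on MDA-MB-231 cells (Homo sapiens) for cytotoxicity, read by MTT assay, with a stated time of 72 h (a higher number here means that more compound is needed for the effect, a lower number that less compound is needed), compound 1 gives 3.9 ug/mL
- compound 2 `CCc1cccc2c(OC)c(-c3occ(C)c3C(=O)NC)ccc12`: in this assay compound 2 gives only a limit, > 10 ug/mL

Compound 2 stands on a limit of this assay rather than on a number, at the limit of > 10 ug/mL in this assay, at which 1 of the 2 values shown sits. Within the data shown here, the single measured step, an at least 2.5-fold higher number from compound 1 to compound 2 (0.40 log units; beyond the scatter), puts compound 2 at the weaker end of the two measured compounds, the change being methylamino in place of ethoxy on a carbonyl carbon.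

Compound 3 `CCc1cccc2c(OC)c(-c3occ(C)c3COC)ccc12` is not yet measured. It differs from compound 2 by methoxymethyl in place of methylcarbamoyl on an aromatic carbon. The amide carbonyl and its hydrogen-bond donor leave; a methoxymethyl ether enters at the same aromatic carbon. Among the measured compounds shown here, the only step that bears on this position is an at least 2.5-fold higher number from compound 1 to compound 2 (0.40 log units; beyond the scatter), where the ester carried the lower number and the amide the higher one. Compound 2 is only a limit, and the step to compound 3 therefore has no firm anchor. Compound 3 is estimated at 8 ug/mL, with a range from 3 ug/mL to 20 ug/mL. The expected step of an at least 1.2-fold lower number from compound 2 to compound 3 (0.09 log units; that floor lies within the scatter) is a modest move downward from the limit, though a second limit would not surprise.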

Compound 3, concentration for half-maximal effect: 9.7 ug/mL
Beside the measured number, compound 3's estimate is 1.2-fold (0.08 log units) below it, and the stated range covers the measured number.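

Placing methoxymethyl instead of ethoxycarbonyl on this aromatic carbon gives a 2.5-fold higher number from compound 1 to compound 3 (0.40 log units; beyond the scatter) in this assay, so at this position an ether without a carbonyl does not match the ester. The comparison with the amide gives only a floor, an at least 1.0-fold lower number from compound 2 to compound 3 (0.01 log units; that floor lies within the scatter), so no order can be stated between these two compounds, and removing the methylcarbamoyl group with its hydrogen-bond donor does not return the number to that of compound 1. Compound 2 remains a limit of the assay and not a number, which restricts any reading of the amide: the limit of > 10 ug/mL in this assay, at which 1 of the 3 values shown sits.

Of the three groups compared at this aromatic carbon, only the ethoxycarbonyl group is tied to the lower number, and the compounds shown cannot tell whether the carbonyl, the ester oxygen or the ethyl chain matters for that. From the compounds shown here alone, a carboxylic acid, a methyl ester, a longer ester chain or a hydroxymethyl group at this aromatic carbon would help separate these possibilities, while the amide's true value in this assay stays open.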